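From Ethyl to Isopropyl on a Shared Core

This account rests on a few compounds, and the source may have more. Where it says the series, first, only, none or still open, it means among the compounds named here.

Compound 2 `CCc1ccc(N/N=C2\CCC(C)n3c2ncc(C(=O)O)c3=O)cc1` carries an ethyl group. In a functional assay on the whole organism for inhibition, with Rattus norvegicus as the target (a higher number here means that more compound is needed for the effect, a lower number that less compound is needed), compound 2 gives only a limit, > 1000 umol/kg. Compound 1 `CC1CC/C(=N\Nc2ccc(I)cc2)c2ncc(C(=O)O)c(=O)n21` likewise gives only a limit in this assay, > 1000 umol/kg. Between them stands a step that the two limits leave unreadable from compound 1 to compound 2, and both values sit at the limit of > 1000 umol/kg in this assay, at which 2 of the 2 values shown sit. Compound 3 `CC(C)c1ccc(N/N=C2\CCC(C)n3c2ncc(C(=O)O)c3=O)cc1` differs from compound 2 by methyl in place of hydrogen on a saturated chain carbon bound to an aromatic carbon and a saturated chain carbon. Among the measured compounds shown here, no measured step reads the size of such a change, so the expected step in this assay is a step that the limit leaves unreadable from compound 2 to compound 3, with no direction beyond the scatter. Compound 3 is expected at 2000 umol/kg, most likely again a limit, within 500 umol/kg to 10000 umol/kg.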

Compound 3, dose for 50% inhibition: > 100 umol/kg
Compound 3: only a limit was reported; the forecaster's own chance of this, stated with the estimate: 85%; the middle value is on the limit's open side.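

Among the compounds shown here, all three values in this assay are limits, so no step among compound 1, compound 2 and compound 3 can be read. The compounds shown leave open how iodo, ethyl and isopropyl actually compare on the shared core.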